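Swapping a Fluorophenyl for Pyridyl in a Hydrazone Series

A few compounds are considered here, and "the series" means these few. Any claim that something is new, unique, unknown or untested is made for them only; others in the source may bear on it.

Measured compounds:
compound 1, `CCOC(=O)C(F)Oc1ccccc1/C=N/NC(=O)COc1ccc(Cl)cc1C`, in an ADME assay on cells for inhibition of anoctamin-2 (Homo sapiens), read by fluorescence, with a stated time of 20 min (a higher number here means a weaker inhibitor, a lower number a stronger inhibitor), gives 59400 nM.
compound 2, `Cc1cc(Cl)ccc1OCC(=O)N/N=C/c1ccccc1F`, in this assay gives "not active" (no number reported).

Within the data shown here, only two compounds have been measured. Compound 1 sits at a very weak level in this assay, and compound 2 is recorded there with no number at all, only the statement that it showed no activity. Compound 2 therefore cannot be placed on a scale of concentrations; all that is known is that it failed to register an inhibitory concentration in this assay. Among the measured compounds shown here, no pair of measured compounds differs in one place, so no step size is available.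

Compound 3, `Cc1cc(Cl)ccc1OCC(=O)N/N=C/c1ccccn1`, is the next compound to be tested. It differs from compound 2 in one place: pyridin-2-yl in place of 2-fluorophenyl on a carbon with a double bond to nitrogen. With compound 2 giving no number and compound 1 being very weak, there is nothing to suggest a large move in either direction in this assay; the expectation is for a weak result or again no measurable activity. For compound 3 the estimated value in this assay is 100000 nM, expected to fall between 30000 nM and 300000 nM.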

Compound 3, half-maximal inhibitory concentration: > 100000 nM
Compound 3: only a limit was reported (the forecaster's own chance of this, stated with the estimate: 70%); the middle value sits exactly at the limit.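

In this assay compound 3 gives > 100000 nM, which is a limit and not a number. Compound 2 has no number either, so no step can be read between compound 2 and compound 3. The compounds shown leave open whether pyridin-2-yl and 2-fluorophenyl differ at all in their effect on inhibition at this place.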